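The source may hold more compounds than are shown below. What is called first, only, known or untested is meant among the compounds shown, and "the series" means these compounds.

The set shares one core, carried by compound 1 `O=C(Nc1ccccc1)c1c(NO)cc(-c2ccc(Cl)cc2)oc1=O`, compound 2 `Cc1ccc(-c2cc(NO)c(C(=O)Nc3ccccc3)c(=O)o2)cc1` and compound 3 `O=C(Nc1ccc(F)cc1)c1c(NO)cc(-c2ccccc2)oc1=O`, and extends to the not yet measured compound 4 `O=C(Nc1ccc(O)cc1)c1c(NO)cc(-c2ccccc2)oc1=O`. In an ADME assay on Huh-7 cells (Homo sapiens) for cytotoxicity, read by a luciferase reporter and WST assay, with a stated time of 3 days (on this read-out lower numbers stand for higher toxicity in this test and higher numbers for lower toxicity in this test), compound 1 gives 11000 nM. For compound 2 this assay reports only a limit, > 20000 nM. Compound 3 likewise reaches only a limit in this assay, namely > 20000 nM. Compound 3 therefore stands where the read-out stops, a position described by the limit of > 20000 nM in this assay, at which 2 of the 3 values shown sit. Within the data shown here, the single measured step, an at least 1.8-fold higher number from compound 1 to compound 2 (0.25 log units; that floor lies within the scatter), runs from a number to a limit, so its true size is known only as a floor. The change to compound 4 is hydroxy in place of fluoro on an aromatic carbon. Among the measured compounds shown here, no measured step touches this position of the anilide ring; the one step recorded concerns the other aromatic ring, and it shows only that a small change on an aromatic carbon stayed within the scatter or at the limit. On that basis no step beyond the scatter is expected in this assay, and the step that the limit leaves unreadable from compound 3 to compound 4 that the estimate means is expected to be small. Compound 4 is accordingly estimated at 22000 nM, within a range from 9000 nM to 50000 nM, with a fair chance that only a limit is reported again.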

Compound 4, half-maximal cytotoxic concentration: > 20000 nM
Compound 4: a limit, no number (the forecaster's own chance of this, stated with the estimate: 65%); the middle value is on the limit's open side.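

In this assay compound 4 reaches only a limit, > 20000 nM. Among these compounds, compound 3 is also reported only as a limit, so no step between compound 3 and compound 4 can be read. The compounds shown leave open whether hydroxy in place of fluoro on the aromatic carbon changes the half-maximal cytotoxic concentration at all.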